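The source may report more compounds than this note shows. Statements on the series, on what has been measured and on what is new or still open speak of the compounds shown alone.

Measured so far:
compound 1 `O=c1c2cnn(-c3ccc(F)cc3)c2ncn1CC1(O)CCN(Cc2ccccc2Cl)CC1`: 3400 nM
compound 2 `O=c1c2cnn(-c3ccc(F)cc3)c2ncn1CC1(O)CCN(Cc2ccccc2Br)CC1`: 3100 nM
compound 3 `COC(=O)c1ccc(CN2CCC(O)(Cn3cnc4c(cnn4-c4ccc(F)cc4)c3=O)CC2)c(Cl)c1`: 800 nM

All three values come from an assay on Sf21 cells for inhibition of ubiquitin carboxyl-terminal hydrolase 7 (Homo sapiens), read by spectrophotometry, with stated times of 30 min and 2 h; a higher number here means a weaker inhibitor, a lower number a stronger inhibitor. Compound 4 `COC(=O)c1ccc(CN2CCC(O)(Cn3cnc4c(cnn4-c4ccc(F)cc4)c3=O)CC2)c(Br)c1` is the one still to be run in this assay.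

Compound 4 is built from compound 3 by the change (bromo in place of chloro on an aromatic carbon). The same kind of change is already on record once, from compound 1 to compound 2: bromo in place of chloro on an aromatic carbon. There it made the step of a 1.1-fold lower number from compound 1 to compound 2 (0.04 log units; within the scatter), so the two halogens read as interchangeable within this pair.

The two cores on which the change is made are not identical. Compound 3 differs from compound 1 by methoxycarbonyl in place of hydrogen on an aromatic carbon, and that difference gave the step of a 4.3-fold lower number from compound 1 to compound 3 (0.63 log units; beyond the scatter). Accordingly the place of the halogen swap is not described in identical words in the two pairs: in compound 1 to compound 2 it is ortho to a large group only, whereas in compound 3 to compound 4 it is ortho to a large group and also meta to a methoxycarbonyl group. The change from compound 3 to compound 4 is thus the same kind of change as from compound 1 to compound 2, not the same change.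

Among the measured compounds shown here, the expectation for compound 3 to compound 4 in this assay is a step within the scatter, a 1.1-fold lower number from compound 3 to compound 4 (0.03 log units; within the scatter), and that rests on the single earlier instance, compound 1 to compound 2 with a 1.1-fold lower number from compound 1 to compound 2 (0.04 log units; within the scatter). On that basis compound 4 is estimated at 750 nM, with a range of 400 nM to 1400 nM expected.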

Compound 4, half-maximal inhibitory concentration: 900 nM
For compound 4 the middle estimate is 1.2-fold (0.08 log units) below the measured one; the range from low to high includes it.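

In this assay the swap of bromo for chloro, here a 1.1-fold higher number from compound 3 to compound 4 (0.05 log units; within the scatter), carries from one core to the other with no detectable difference between the two steps: the same change on two cores in this assay, a 1.1-fold lower number (0.04 log units; within the scatter) from compound 1 to compound 2 and a 1.1-fold higher number (0.05 log units; within the scatter) from compound 3 to compound 4, 1.2-fold (0.09 log units) apart, within the scatter of two such steps. Read the other way, the gain from methoxycarbonyl in place of hydrogen holds with bromo as it does with chloro, here a 3.4-fold lower number from compound 2 to compound 4 (0.54 log units; beyond the scatter), and the two steps agree: the same change on two cores in this assay, a 4.3-fold lower number (0.63 log units; beyond the scatter) from compound 1 to compound 3 and a 3.4-fold lower number (0.54 log units; beyond the scatter) from compound 2 to compound 4, 1.2-fold (0.09 log units) apart, within the scatter of two such steps. Among the compounds shown here, the two changes taken together give a 3.8-fold lower number from compound 1 to compound 4 (0.58 log units; beyond the scatter), which fits simple additivity across these four compounds, but the evidence is only two matched pairs for each change, with one halogen place and one methoxycarbonyl place, so it shows nothing about the swap elsewhere on the ring or on a different core.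

On these data alone, whether the gain belongs to methoxycarbonyl itself remains open, since a carboxylic acid, a primary amide or a nitrile at that place would separate the ester from other groups. Also open, as far as these compounds go, is whether any halogen is needed at the place of the swap, a question that fluoro, methyl or plain hydrogen there, on the ring that carries the methoxycarbonyl group, would address.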